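From propanoyl to propylcarbonyl: one added methyl on compound 2

The source may hold more compounds than are shown below. What is called first, only, known or untested is meant among the compounds shown, and "the series" means these compounds.

Going by the values given here, only two compounds have values so far. In a functional assay on the whole organism with Mus musculus as the target, in the maximal electroshock model (on this read-out higher numbers stand for an effect only at larger amounts of compound and lower numbers for an effect already at smaller amounts), compound 1 `CCCC(=O)OC1CCN(c2ccc(-c3ccccc3Cl)nn2)CC1` gives 28 mg/kg and compound 2 `CCC(=O)OC1CCN(c2ccc(-c3ccc(Cl)cc3Cl)nn2)CC1` gives 50 mg/kg. These two values lie within the scatter of each other, so compound 2 stands level with compound 1.

Compound 3 `CCCC(=O)OC1CCN(c2ccc(-c3ccc(Cl)cc3Cl)nn2)CC1` is still unmeasured. It differs from compound 2 by a single change, methyl in place of hydrogen on a saturated chain carbon, two bonds along the chain from a carbonyl carbon. Among the compounds with values here, no measured pair yet isolates a single change, so the expectation rests on these two values alone. In this assay no step beyond the scatter is expected, in either direction. The estimated step is a 1.3-fold lower number from compound 2 to compound 3 (0.12 log units; within the scatter), which stays within the scatter. The expected value for compound 3 is 38 mg/kg, with an estimated range of 18 mg/kg to 80 mg/kg.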

Compound 3, dose for half-maximal effect: 50 mg/kg
Compound 3: middle estimate off by 1.3-fold (0.12 log units), on the low side; low and high end bracket the measured number.
By their numbers in this assay, from the lowest: compounds 1, 2 and 3 (each within the scatter of the next).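

In this assay the series now has its first pairs that differ in one place: methyl in place of hydrogen on a saturated chain carbon, two bonds along the chain from a carbonyl carbon, gives no change at the digits printed from compound 2 to compound 3 (within the scatter) and chloro in place of hydrogen on an aromatic carbon gives a 1.8-fold higher number from compound 1 to compound 3 (0.25 log units; within the scatter) on the same read-out. Neither step lies beyond the scatter, so on these three compounds neither the propanoyl to propylcarbonyl exchange nor the added chloro separates any pair on this read-out. No measurement shown here bears on a reason for either step.

The compounds shown leave open whether a longer chain on this carbonyl would give a step beyond the scatter. The same holds for an amine in place of the propylcarbonyl group.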